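A few compounds are considered here, and "the series" means these few. Any claim that something is new, unique, unknown or untested is made for them only; others in the source may bear on it.

Working notes on the aminothiophene series

Of the compounds shown here, three sharing one core have been tested in an in vitro assay on CHOk1 cells with adenosine receptor A1 (Homo sapiens) as the target; a higher number here means that more compound is needed for the effect, a lower number that less compound is needed. Compound 1 `CCOC(=O)c1c(N)sc2c1CCNC2` gives 11700 nM. Compound 2 `Nc1sc2c(c1C(=O)O)CCN(Cc1ccccc1)C2` gives 8000 nM. Compound 3 `CC(C)(C)OC(=O)N1CCc2c(sc(N)c2C(=O)O)C1` gives 12100 nM. The three numbers lie within the usual scatter of one another, so compound 2 cannot be separated from compound 1 or compound 3 on these figures; the series as a whole sits in a weak range in this assay. Going by the values given here, no pair of measured compounds differs in a single place, so no clean step can be read from them.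

Compound 4 `Nc1sc2c(c1C(=O)NNc1ccccc1)CCN(Cc1ccccc1)C2` is the next member to be measured in this assay. It differs from compound 2 by anilinoamino in place of hydroxy on a carbonyl carbon. Whether the ester of compound 1 or the acid of compound 2 is present makes no difference beyond the scatter, but a change of this kind on the carbonyl carbon has not been tested in the series, so the step is open. The expectation is for a modest shift towards a lower number, of a size that may or may not exceed the scatter, written as a 2.7-fold lower number from compound 2 to compound 4 (0.43 log units; beyond the scatter). Compound 4 is therefore estimated at 3000 nM, with a range from 500 nM to 20000 nM.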

Compound 4, half-maximal effective concentration: 7800 nM
Beside the measured number, compound 4's estimate is 2.6-fold (0.41 log units) below it, and the stated range covers the measured number.
By their numbers in this assay, from the lowest: compounds 4, 2, 1 and 3 (each within the scatter of the next).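

Going by these compounds alone, this is the first single-place step, and it concerns the carbonyl carbon: anilinoamino in place of hydroxy gives a 1.0-fold lower number from compound 2 to compound 4 (0.01 log units; within the scatter) in this assay. The group that enters brings eight heavy atoms and a six-membered aromatic ring of carbon only, yet the figures cannot separate the two compounds, so this position accepts a much larger group without a measurable consequence here, at least for this one replacement on the benzyl-bearing compound. No evidence at hand bears on this result.

On these data alone, whether anything placed on the carbonyl carbon can take the series beyond the scatter remains open, since a single replacement cannot show this for an amino group, a methoxy group, or a longer chain linking the carbonyl to the phenyl ring. The role of the benzyl group is open as well, as no single-place step among the compounds shown touches it, and a methyl group or a phenethyl group in that place would be needed to read it.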